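A Trifluoromethyl Swap Near the Cytotoxicity Limit

The source may report more compounds than this note shows. Statements on the series, on what has been measured and on what is new or still open speak of the compounds shown alone.

Three related compounds have been tested so far. In an ADME assay on BJ cells (Homo sapiens) for cytotoxicity, with a stated time of 72 h (on this read-out lower numbers stand for an effect already at smaller amounts and higher numbers for an effect only at larger amounts of compound), compound 1 `CSc1ccc(NC(=O)Nc2cc(C)nc3ccccc23)cc1` returns > 25000 nM as a limit and not as an exact number. Compound 2 `Cc1cc(NC(=O)Nc2cccc([N+](=O)[O-])c2)c2ccccc2n1` likewise returns > 25000 nM as a limit of this assay and not as an exact number. Within the data shown here, compound 3 `Cc1cc(NC(=O)Nc2ccccc2C(C)(C)C)c2ccccc2n1` gives 22000 nM and so holds the only true number among the three.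

Compound 4 `Cc1cc(NC(=O)Nc2ccccc2C(F)(F)F)c2ccccc2n1` has not yet been measured. Compared with compound 3, it carries trifluoromethyl in place of tert-butyl on an aromatic carbon. Among the measured compounds shown here, no two tested compounds differ in only one place, so the data offer no direct precedent for this swap.

A step within the usual scatter is expected in this assay with no firm direction because compound 3 gives 22000 nM and the series offers no larger number to suggest otherwise. The nearby boundary is the limit of > 25000 nM in this assay, at which 2 of the 3 values shown sit, and a bare limit for compound 4 would therefore be no surprise. The expected change is small, an estimated 1.1-fold higher number from compound 3 to compound 4 (0.06 log units; within the scatter) in all. For compound 4 the estimate is 25000 nM with an expected range from 13000 nM to 45000 nM as the likely span.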

Compound 4, half-maximal effective concentration: > 25000 nM
Compound 4 gave a limit, no number; the forecaster's own chance of this, stated with the estimate: 55%; the middle value lies on the limit itself.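

Swapping tert-butyl for trifluoromethyl on an aromatic carbon ortho to a large group gives, in this assay, an at least 1.1-fold higher number from compound 3 to compound 4 (0.05 log units; that floor lies within the scatter). Compound 4 returns > 25000 nM, which is a limit and not a number, so this change is now tied to a lowest possible size for the step but not to a true size. The swap brings no sign of an effect at smaller amounts of compound, and the one exact number in the series is left standing alone, with the other compounds gathered at the top of the measurable range: the limit of > 25000 nM in this assay, at which 3 of the 4 values shown sit.

The compounds shown leave open how far the true value of compound 4 lies from that limit, and so whether the step is larger than the usual scatter or stays within it. They also leave open what an amine, a carboxylic acid or a longer chain would do at this same place, and whether any such group would bring the read-out down to exact numbers that could be compared directly.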